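A few compounds are considered here, and "the series" means these few. Any claim that something is new, unique, unknown or untested is made for them only; others in the source may bear on it.

Of the compounds shown here, three sharing one core have been measured: compound 1 `O=C(/C=C/c1ccccc1)c1nc2ccccc2[nH]1`, compound 2 `O=C(/C=C/c1cccnc1)c1nc2ccccc2[nH]1` and compound 3 `Cc1ccccc1/C=C/C(=O)c1nc2ccccc2[nH]1`. In a functional assay on HepG2 cells (Homo sapiens) for antiproliferative activity, read by MTT assay, with a stated time of 48 h (on this read-out lower numbers stand for stronger inhibition and higher numbers for weaker inhibition), compound 1 gives 6300 nM, compound 2 gives 8480 nM and compound 3 gives 6710 nM. Compound 1 has the lowest of the three numbers, but the other two sit within the usual scatter of it, as seen in a 1.3-fold higher number from compound 1 to compound 2 (0.13 log units; within the scatter) and a 1.1-fold higher number from compound 1 to compound 3 (0.03 log units; within the scatter). Compound 4 `O=C(/C=C/c1cccc(Br)c1)c1nc2ccccc2[nH]1` has not yet been measured. Compared with compound 1 it shows (bromo in place of hydrogen on an aromatic carbon). The nearest guide is the step from compound 1 to compound 3, where methyl in place of hydrogen on an aromatic carbon left the number essentially unchanged; the swap to pyridin-3-yl in compound 2 also moved little. Within the data shown here, no measured step involves bromo itself, so the expectation rests on these two small moves alone. Compound 4 is therefore expected to show a 1.1-fold lower number from compound 1 to compound 4 (0.06 log units; within the scatter), a shift no larger than the scatter. The estimate for compound 4 is 5500 nM, with a range from 2500 nM to 12000 nM.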

Compound 4, half-maximal inhibitory concentration: 1590 nM
Compound 4: middle estimate off by 3.5-fold (0.54 log units), on the high side; measured number outside the range, below it.
By their numbers in this assay, from the lowest: compound 4; then compounds 1, 3 and 2 (each within the scatter of the next).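

The bromo step gives a 4.0-fold lower number from compound 1 to compound 4 (0.60 log units; beyond the scatter) in this assay. Among these compounds, this shows that a change of one heavy atom on this six-membered aromatic ring can move the number beyond the scatter, which the earlier steps gave no sign of: methyl gave a 1.1-fold higher number from compound 1 to compound 3 (0.03 log units; within the scatter), and pyridin-3-yl in place of phenyl gave a 1.3-fold higher number from compound 1 to compound 2 (0.13 log units; within the scatter). No measurement shown here bears on what lies behind the bromo step.

On these data alone, whether the lower number belongs to bromo itself or would also appear with chloro, fluoro or methoxy on the same carbon remains open. As far as these compounds go, only compound 4 carries bromo, so it also remains open whether bromo on another carbon of this ring would give a similar number.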